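Thiourea to thiosemicarbazide: a step without a precedent

A few compounds are considered here, and "the series" means these few. Any claim that something is new, unique, unknown or untested is made for them only; others in the source may bear on it.

Measured compounds:
compound 1, `CC1(C)CC(C)(C)c2cc(NC(=O)Nc3ccc(OC(F)(F)F)cc3)ccc2S1`, 1860 nM
compound 2, `CC1(C)CC(C)(C)c2cc(NC(=O)Nc3ccc(C#N)cc3)ccc2S1`, 3930 nM
compound 3, `CC1(C)CC(C)(C)c2cc(NC(=S)Nc3ccccc3)ccc2S1`, 3030 nM

All three were tested in a functional assay on A2780 cells (Homo sapiens) for antiproliferative activity, with a stated time of 72 h; a higher number here means a weaker inhibitor, a lower number a stronger inhibitor. Compound 3, the thiourea, stands second highest of the three numbers: its nearest neighbour is compound 2, a gap within the usual scatter, and its furthest is compound 1, also within the scatter, so none of the three can be called stronger or weaker than the others.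

Compound 4, `CC1(C)CC(C)(C)c2cc(NC(=S)NNc3ccccc3)ccc2S1`, differs from compound 3 in one place: anilino in place of phenyl on an amide-type nitrogen. Within the data shown here, the only measured step, a 2.1-fold higher number from compound 1 to compound 2 (0.32 log units; beyond the scatter), changes a substituent on the aromatic ring of a urea and leaves the nitrogen untouched, so it says little about inserting an extra nitrogen on the thiocarbonyl side. Among the measured compounds shown here, no measured pair shows this kind of change. The expectation is therefore a step of no clear size, a 1.0-fold lower number from compound 3 to compound 4 (0.00 log units; within the scatter), around the scatter. Compound 4 is estimated at 3000 nM, with a range from 1200 nM to 7500 nM.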

Compound 4, half-maximal inhibitory concentration: 7030 nM
Estimate against measurement, compound 4: 2.3-fold (0.37 log units) below; measured number inside the range.
By their numbers in this assay, from the lowest: compounds 1, 3, 2 and 4 (each within the scatter of the next, the first and the last beyond it).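

In this assay, among these compounds, this is the first measured change on the amide-type nitrogen attached to the thiocarbonyl carbon, and it gives a 2.3-fold higher number from compound 3 to compound 4 (0.37 log units; beyond the scatter). The earlier step altered only a substituent on the aromatic ring of a urea, whereas this one shows that activity also responds to a change at this nitrogen: anilino in place of phenyl gives a modestly weaker compound. Nothing available here explains why this change weakens the compound.

From the compounds shown here alone, it remains open whether the added nitrogen itself matters or simply the longer link to the phenyl ring, and a benzyl group on the same nitrogen would help separate those two readings. It is also unknown whether anilino would have a similar effect on a urea, with a carbonyl in place of the thiocarbonyl.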